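Chloro for methoxy among limit values

The compounds below may be only part of what the source reports. "The series", "measured", "known", "first", "only" and "open" are said of these compounds alone.

In an ADME assay on J774 cells (Mus musculus) for cytotoxicity (on this read-out higher numbers stand for an effect only at larger amounts of compound and lower numbers for an effect already at smaller amounts), compound 1 `Cc1[nH]c2ccccc2c(=O)c1Cc1ccccc1` gives only a limit (> 40100 nM). Compound 2 `Cc1[nH]c2ccccc2c(=O)c1Br` also gives a limit (> 42000 nM). Compound 3 `COc1cccc2c(=O)c(Cc3ccccc3)c(C)[nH]c12` stands at a limit too (> 35800 nM), so it has no number and no rank among the three.

Compound 4 `Cc1[nH]c2c(Cl)cccc2c(=O)c1Cc1ccccc1` carries chloro in place of methoxy on an aromatic carbon, ortho to a fused ring (chloro in place of methoxy on an aromatic carbon). Among the compounds with values here, the one measured step that bears on this site, a step that the two limits leave unreadable from compound 1 to compound 3, introduces the methoxy and offers no size to carry over. No step beyond the scatter is therefore expected in this assay, and the expected change is an at least 1.0-fold lower number from compound 3 to compound 4 (0.00 log units; that floor lies within the scatter). Compound 4 is estimated at 35000 nM, with an expected range of 15000 nM to 45000 nM, and will probably be reported as a limit.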

Compound 4, half-maximal effective concentration in the J774 assay: > 35200 nM
Compound 4 ended at the assay's limit (the forecaster's own chance of this, stated with the estimate: 80%); middle value at least 1.0-fold (0.00 log units) from the limit.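

In the J774 assay compound 1 gives only a limit, > 40100 nM. In the J774 assay compound 3 also gives only a limit, > 35800 nM. In the J774 assay compound 4 likewise gives only a limit, > 35200 nM. With all three at limits, neither step to compound 4 can be read. The compounds shown leave open whether chloro or methoxy on this aromatic carbon shifts the half-maximal effective concentration at all. In a physicochemical assay for lipophilicity, at pH 7.4 (on this read-out higher numbers stand for higher lipophilicity and lower numbers for lower lipophilicity), compound 3 gives 2.24 and compound 4 gives 2.78. In the physicochemical assay chloro in place of methoxy gives a number 0.54 log units higher from compound 3 to compound 4 (beyond the scatter).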